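This account rests on a few compounds, and the source may have more. Where it says the series, first, only, none or still open, it means among the compounds named here.

Two ureas built on the shared core of compound 2 have been tested in an ADME assay on NCM460 cells (Homo sapiens) for cytotoxicity, read by MTT assay, with a stated time of 72 h, in the presence of a further agent that is not named here; on this read-out higher numbers stand for an effect only at larger amounts of compound and lower numbers for an effect already at smaller amounts. Compound 1 `Cn1ccc2c(-c3ccccc3)nc(NNC(=O)Nc3cc(Cl)nc(Cl)c3)nc21` gives 683000 nM in this assay. Compound 2 `O=C(Nc1ccnc(Cl)c1)Nc1cc(Cl)nc(Cl)c1` gives 55300 nM in this assay, the lower of the two numbers, and the gap between compound 2 and compound 1 is beyond the scatter, so compound 2 is the one that acts already at the smaller amount among the pair.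

Compound 3 `O=C(Nc1cc(Cl)nc(Cl)c1)Nc1cc(Cl)nc(OC2CCCC2)c1` has not yet been measured in this assay. It differs from compound 2 in one place: cyclopentyloxy in place of hydrogen on an aromatic carbon. Among the measured compounds shown here, no comparison of measured compounds covers such a change, so nothing in the data points to a direction. The step from compound 2 to compound 3 in this assay is expected to be small, probably within the scatter, with a slight lean toward a lower number a 1.4-fold lower number from compound 2 to compound 3 (0.14 log units; within the scatter). Compound 3 is therefore estimated at 40000 nM in this assay, within a range from 12000 nM to 150000 nM.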

Compound 3, half-maximal effective concentration: 21400 nM
Compound 3: middle estimate off by 1.9-fold (0.27 log units), on the high side; the measured number falls inside the stated range.
By their numbers in this assay, from the lowest: compound 3; then compound 2; then compound 1.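

In this assay, cyclopentyloxy in place of hydrogen on an aromatic carbon next to the ring nitrogen gives a 2.6-fold lower number from compound 2 to compound 3 (0.41 log units; beyond the scatter), a modest step. Among the compounds shown here, it shows that this position accepts a group with a five-membered non-aromatic ring of carbon only, and that the number moves toward an effect at smaller amounts; the earlier compounds held no comparison at this place. Nothing at hand gives a reason for this step.

The compounds shown leave open whether the step belongs to cyclopentyloxy itself or would also follow from a methoxy group, an amine or a longer chain on the same carbon. They also leave open whether the same change would shift the number in the same direction on the core of compound 1.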